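Removing a methyl from an aromatic oxygen on the quinazolinone hydrazones

A few compounds are considered here, and "the series" means these few. Any claim that something is new, unique, unknown or untested is made for them only; others in the source may bear on it.

Measured compounds:
compound 1 `COc1ccc(/C=N/NC(=O)CCCc2nc3ccccc3c(=O)[nH]2)cc1` gives 247000000 nM in a physicochemical assay, read by spectrophotometry, with a stated time of 30 min; a higher number here means a weaker inhibitor, a lower number a stronger inhibitor
compound 2 `COc1cc(/C=N/NC(=O)CCc2nc3ccccc3c(=O)[nH]2)cc(OC)c1O` gives 126000000 nM in this assay
compound 3 `COc1cc(/C=N/NC(=O)CCc2nc3ccccc3c(=O)[nH]2)cc(O)c1O` gives 104000000 nM in this assay

Compound 1 carries the highest number of the three, though compound 2 lies within the scatter of it. The difference between the core of compound 1 and the core of compound 2 is not broken down here. Compound 2 and compound 3 differ in one place, (hydrogen in place of methyl on an oxygen on an aromatic ring), and that change gave a 1.2-fold lower number from compound 2 to compound 3 (0.08 log units; within the scatter).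

Compound 4 `O=C(CCCc1nc2ccccc2c(=O)[nH]1)N/N=C/c1ccc(O)cc1` has not been measured. It differs from compound 1 by hydrogen in place of methyl on an oxygen on an aromatic ring, the same change as seen between compound 2 and compound 3, made at the same kind of place. Because the earlier step was a 1.2-fold lower number from compound 2 to compound 3 (0.08 log units; within the scatter), the step from compound 1 to compound 4 is expected to be of similar size, a 1.2-fold lower number from compound 1 to compound 4 (0.09 log units; within the scatter). Compound 4 is therefore estimated at 200000000 nM in this assay, between 100000000 nM and 400000000 nM.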

Compound 4, half-maximal inhibitory concentration: 214000000 nM
Estimate against measurement, compound 4: 1.1-fold (0.03 log units) below; measured number inside the range.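

In this assay the change from methoxy to hydroxy gave a 1.2-fold lower number from compound 1 to compound 4 (0.06 log units; within the scatter) on one core and a 1.2-fold lower number from compound 2 to compound 3 (0.08 log units; within the scatter) on the other, so the small step seen on one core was also small on the second. This does not show that the change has no effect at all, and two pairs cannot say how it would behave on a further core. Nothing shown explains why the step stays this small.

The compounds shown leave open what an amine or a carboxylic acid would give at that place on the aromatic ring. They also leave open whether a longer chain on that oxygen, such as ethyl, would give a step beyond the scatter.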